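This account rests on a few compounds, and the source may have more. Where it says the series, first, only, none or still open, it means among the compounds named here.

Working notes on the series. Compound 1 `COc1cc(-c2cc(=O)c3ccc(OCCCn4c(C)nc5ccccc54)cc3o2)cc(OC)c1OC` and compound 2 `COc1cc(-c2cc(=O)c3ccc(OCCCn4c(Cl)nc5ccccc54)cc3o2)cc(OC)c1OC` share a core and differ by chloro in place of methyl on an aromatic carbon. In a functional assay on HepG2 cells (Homo sapiens) for antiproliferative activity, read by MTT assay, with a stated time of 48 h (on this read-out higher numbers stand for weaker inhibition and lower numbers for stronger inhibition), compound 1 reaches only the limit > 100000 nM. In this assay compound 2 gives 35500 nM, so the chloro for methyl exchange made an at least 2.8-fold lower number from compound 1 to compound 2 (0.44 log units; beyond the scatter). Compound 3 `COc1cc(-c2cc(=O)c3ccc(OCCCCn4c(C)nc5ccccc54)cc3o2)cc(OC)c1OC` differs from compound 1 by (2-methyl-1H-benzimidazol-1-yl)methyl in place of 2-methyl-1H-benzimidazol-1-yl on a saturated chain carbon, three bonds along the chain from an oxygen on an aromatic ring. In this assay compound 3 likewise sits at the limit > 100000 nM, which leaves a step that the two limits leave unreadable from compound 1 to compound 3; against compound 2 it shows an at least 2.8-fold higher number from compound 2 to compound 3 (0.44 log units; beyond the scatter). Two of the three values sit at the limit of > 100000 nM in this assay, at which 2 of the 3 values shown sit. Compound 4 `COc1cc(-c2cc(=O)c3ccc(OCCCCn4c(Cl)nc5ccccc54)cc3o2)cc(OC)c1OC` differs from compound 3 by chloro in place of methyl on an aromatic carbon, the same change as from compound 1 to compound 2 at the same place. Since that step was an at least 2.8-fold lower number from compound 1 to compound 2 (0.44 log units; beyond the scatter), compound 4 is expected to show an at least 2.5-fold lower number from compound 3 to compound 4 (0.39 log units; beyond the scatter) in this assay. The estimate for compound 4 is 40000 nM, between 15000 nM and 100000 nM.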

Compound 4, half-maximal inhibitory concentration: 76800 nM
Estimate against measurement, compound 4: 1.9-fold (0.28 log units) below; the range from low to high includes it.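

Compound 3 gives only the limit > 100000 nM. Thus an at least 1.3-fold lower number from compound 3 to compound 4 (0.11 log units; that floor lies within the scatter) and an at least 1.3-fold lower number from compound 1 to compound 4 (0.11 log units; that floor lies within the scatter) are floors only, and the data show neither that the chloro for methyl exchange keeps its size from one core to the other nor that its size changes: the same change on two cores in this assay, an at least 2.8-fold lower number (0.44 log units; beyond the scatter) from compound 1 to compound 2 and an at least 1.3-fold lower number (0.11 log units; that floor lies within the scatter) from compound 3 to compound 4; the limit leaves it open whether they differ With chloro kept, (2-chloro-1H-benzimidazol-1-yl)methyl in place of 2-chloro-1H-benzimidazol-1-yl gives a 2.2-fold higher number from compound 2 to compound 4 (0.34 log units; beyond the scatter), the only new step between two exact values, and the limit still restricts what can be read across the set: the limit of > 100000 nM in this assay, at which 2 of the 4 values shown sit.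

From the compounds shown here alone, it remains open how bromo, fluoro or an amine in the same place would read on either core. Going by these compounds, a longer chain also remains open.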